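The source may report more compounds than this note shows. Statements on the series, on what has been measured and on what is new or still open speak of the compounds shown alone.

Within the data shown here, compound 1 `CC1CC/C(=N\Nc2ccc(O)cc2)c2ncc(C(=O)O)c(=O)n21` stands highest of the two numbers measured so far in a functional assay on the whole organism for inhibition, with Rattus norvegicus as the target (a lower number here means that less compound is needed, a higher number that more compound is needed for the effect), where compound 1 gives 1.7 umol/kg. Compound 2 `Cc1cccc(N/N=C2\CCC(C)n3c2ncc(C(=O)O)c3=O)c1` gives 0.4 umol/kg in this assay, a step of a 4.3-fold lower number from compound 1 to compound 2 (0.63 log units; beyond the scatter). Compound 3 `CC(C)c1ccc(N/N=C2\CCC(C)n3c2ncc(C(=O)O)c3=O)cc1` differs from compound 1 by isopropyl in place of hydroxy on an aromatic carbon. Among the measured compounds shown here, only the step from compound 1 to compound 2 bears on this change, and it was modest yet beyond the scatter, so a lower number in this assay of similar size is expected for compound 3. Compound 3 is estimated at 0.6 umol/kg (range 0.2 umol/kg to 1.8 umol/kg), an expected step of a 2.8-fold lower number from compound 1 to compound 3 (0.45 log units; beyond the scatter).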

Compound 3, dose for 50% inhibition: 2.4 umol/kg
Beside the measured number, compound 3's estimate is 4.0-fold (0.60 log units) below it; measured number outside the range, above it.
By their numbers in this assay, from the lowest: compound 2; then compounds 1 and 3 (each within the scatter of the next).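

In this assay, isopropyl in place of hydroxy on this aromatic carbon, para to a large group, gives a 1.4-fold higher number from compound 1 to compound 3 (0.15 log units; within the scatter) and so leaves the two compounds indistinguishable. Losing the hydroxy therefore does not by itself bring the larger step seen with the 3-methylphenyl group, a 4.3-fold lower number from compound 1 to compound 2 (0.63 log units; beyond the scatter) in this assay. Nothing available explains this result. As far as these compounds go, whether the lower number of compound 2 follows from its methyl group or from where that group sits stays open, as does how a methyl, an amine or a carboxylic acid on this same aromatic carbon would read.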